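Pyridin-4-yl for 3-cyanophenyl: clearance notes

The source may report more compounds than this note shows. Statements on the series, on what has been measured and on what is new or still open speak of the compounds shown alone.

In an in vitro ADME assay on microsomes from liver (Homo sapiens) for metabolic stability (on this read-out higher numbers stand for fast clearance and lower numbers for slow clearance), compound 1 (`CC(C)NC(=O)[C@H]1CC[C@@H](n2/c(=N/C(=O)c3ccc(C#N)c(F)c3)[nH]c3ccc(CN4CCC(C(C)(C)O)CC4)cc32)CC1`) gives 132 mL.min-1.g-1, compound 2 (`CC(C)NC(=O)[C@H]1CC[C@@H](n2/c(=N/C(=O)c3ccc(F)cc3)[nH]c3ccc(CN4CC(C(C)(C)O)C4)cc32)CC1`) gives 105 mL.min-1.g-1 and compound 3 (`CC(C)NC(=O)[C@H]1CC[C@@H](n2/c(=N/C(=O)c3cccc(C#N)c3)[nH]c3ccc(CN4CCC(C(C)(C)O)CC4)cc32)CC1`) gives 72 mL.min-1.g-1. Compound 3 therefore stands within the scatter of both other compounds, and the three numbers do not separate them.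

The next structure is compound 4 (`CC(C)NC(=O)[C@H]1CC[C@@H](n2/c(=N/C(=O)c3ccncc3)[nH]c3ccc(CN4CCC(C(C)(C)O)CC4)cc32)CC1`), with pyridin-4-yl in place of 3-cyanophenyl on a carbonyl carbon. For the measured compounds named here, only one measured step bears on this place: a 1.8-fold lower number from compound 1 to compound 3 (0.26 log units; within the scatter). That step also exchanges one aromatic group for another on the carbonyl carbon, and it stays within the scatter. Going by the values given here, no measured compound carries pyridin-4-yl, so the data give no direction for the change, and no shift beyond the scatter is expected in this assay. The estimated step is a 1.2-fold lower number from compound 3 to compound 4 (0.06 log units; within the scatter). For compound 4 the estimated value is 62 mL.min-1.g-1, with an expected range from 30 mL.min-1.g-1 to 125 mL.min-1.g-1.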

Compound 4, intrinsic clearance in microsomes: 57 mL.min-1.g-1
Compound 4: the middle estimate sits 1.1-fold (0.04 log units) above what was measured; the measured number falls inside the stated range.
By their numbers in this assay, from the lowest: compounds 4, 3, 2 and 1 (each within the scatter of the next, the first and the last beyond it).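

In this assay, exchanging 3-cyanophenyl for pyridin-4-yl on the carbonyl carbon gives a 1.3-fold lower number from compound 3 to compound 4 (0.10 log units; within the scatter), so this replacement of a carbon-only aromatic ring bearing a nitrile by a ring with one hetero atom does not separate the two compounds. For the compounds shown here, the comparison with 4-cyano-3-fluorophenyl gives a 2.3-fold lower number from compound 1 to compound 4 (0.36 log units; beyond the scatter), the only step at this place that passes the scatter, and a modest one, which shows that the read-out at this position can move beyond the scatter when the end groups of the series are compared. No measurement available here accounts for either step.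

Still open, as far as these compounds go, is how a non-aromatic group on this carbonyl carbon, such as cyclohexyl or a short alkyl chain, would read. Pyridin-3-yl and pyridin-2-yl also remain open, as does an amine or a carboxylic acid on the aromatic ring.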